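Replacing Benzyl with 2-(Dimethylamino)ethyl

The source may hold more compounds than are shown below. What is called first, only, known or untested is meant among the compounds shown, and "the series" means these compounds.

Compound 1 `O=C(Nc1ccc(C(=O)N2CCCN(Cc3ccccc3)c3sccc32)cc1)c1ccccc1-c1ccccc1` gives > 0.3 mg/kg in a functional assay on the whole organism for antagonist activity, with Rattus norvegicus as the target (on this read-out higher numbers stand for an effect only at larger amounts of compound and lower numbers for an effect already at smaller amounts), and this value is a limit of the assay, not a number. Compound 2 `CN1CCCN(CCCOc2cc(C(=O)N3CCCCc4sccc43)ccc2NC(=O)c2ccccc2-c2ccccc2)CC1`, a separate compound with a nitrogen-bearing side chain, gives 0.03 mg/kg in this assay. The next compound to be tested is compound 3 `CN(C)CCN1CCCN(C(=O)c2ccc(NC(=O)c3ccccc3-c3ccccc3)cc2)c2ccsc21`. Compared with compound 1, it has this change: (dimethylamino)methyl in place of phenyl on a saturated chain carbon bound to a nitrogen on an aromatic ring in a ring. Read one bond further out, benzyl becomes 2-(dimethylamino)ethyl. For the measured compounds named here, no measured pair shows this change directly, so any forecast in this assay is uncertain. A move to a smaller effective dose, beyond the usual scatter, is expected because compound 2 with its own nitrogen-bearing chain gives 0.03 mg/kg. The expected step is an at least 3.0-fold lower number from compound 1 to compound 3 (0.47 log units; beyond the scatter). For compound 3 the estimated dose is 0.1 mg/kg, with an expected range from 0.02 mg/kg to 0.5 mg/kg.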

Compound 3, dose for 50% inhibition: 0.31 mg/kg
Compound 3: the middle estimate sits 3.1-fold (0.49 log units) below what was measured; the range from low to high includes it.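

No size can be given for the change between compound 1 and compound 3, because the result for compound 1 is a limit and not a number: the limit of > 0.3 mg/kg in this assay, at which 1 of the 3 values shown sits.

The compounds shown leave open how far replacing benzyl with 2-(dimethylamino)ethyl on this shared core shifts the effective dose.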